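A Methyl Moves Along the Saturated Ring

The source may hold more compounds than are shown below. What is called first, only, known or untested is meant among the compounds shown, and "the series" means these compounds.

Compound 1 `Cc1ccc(O)c(C(=O)NCCCN2CCC[C@@H]3CCCC[C@@H]32)c1` is assessed in a functional assay on MDBK cells (Bos taurus) for cytotoxicity; a lower number here means that less compound is tolerated, a higher number that more compound is tolerated. In this assay compound 1 gives > 100 ug/mL, which is a limit of the assay and not a number. Compound 4 `Cc1ccc(O)c(C(=O)NCCCN2CC(C)C[C@@H]3CCCC[C@@H]32)c1` differs from compound 1 by methyl in place of hydrogen on a saturated ring carbon. Going by the values given here, two measured steps concern a methyl entering the same saturated ring at another carbon. Compound 2 `Cc1ccc(O)c(C(=O)NCCCN2[C@H](C)CC[C@@H]3CCCC[C@@H]32)c1` gives 35 ug/mL in this assay, and the step of an at least 2.8-fold lower number from compound 1 to compound 2 (0.45 log units; beyond the scatter). Compound 3 `Cc1ccc(O)c(C(=O)NCCCN2[C@@H](C)CC[C@@H]3CCCC[C@@H]32)c1` gives > 100 ug/mL, a limit. The step that the two limits leave unreadable from compound 1 to compound 3, and the step of an at least 2.8-fold higher number from compound 2 to compound 3 (0.45 log units; beyond the scatter) rests on (the fact that compounds 2 and 3 differ only in the configuration as drawn). One methyl lowered the number while the other stayed at the limit of > 100 ug/mL in this assay, at which 2 of the 3 values shown sit. A small drop or none is therefore expected, and compound 4 is estimated at 80 ug/mL, between 30 ug/mL and 150 ug/mL, meaning an at least 1.2-fold lower number from compound 1 to compound 4 (0.09 log units; that floor lies within the scatter).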

Compound 4, half-maximal cytotoxic concentration: 9.5 ug/mL
Beside the measured number, compound 4's estimate is 8.4-fold (0.93 log units) above it, outside the stated range (below it).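

In this assay, methyl in place of hydrogen two ring bonds from the ring nitrogen gives an at least 10-fold lower number from compound 1 to compound 4 (1.02 log units; beyond the scatter), so this single carbon added to the shared core is enough to lower the number. The lowering is thus not confined to the methyl-bearing carbon of compound 2, although compound 3 goes against it. Nothing shown gives a cause for this step.

On these data alone, the methyl carbon of compound 4 carries no drawn configuration, so whether its two forms would part as compounds 2 and 3 do stays open. As far as these compounds go, whether an ethyl or a hydroxyl group at this carbon would lower the number also stays open.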